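The source may report more compounds than this note shows. Statements on the series, on what has been measured and on what is new or still open speak of the compounds shown alone.

In a functional assay on NCI-H460 cells (Homo sapiens) for cytotoxicity, read by sulforhodamine B assay, with a stated time of 3 days (a lower number here means a stronger inhibitor, a higher number a weaker inhibitor), three related compounds have been measured. Compound 1 (`O=Cc1cn(Cc2cccc(Br)c2)c2ccccc12`) gives 39 nM, compound 3 (`O=[N+]([O-])c1ccc(Cn2cc(CO)c3ccccc32)cc1`) gives 79 nM, and compound 2 (`OCc1cn(Cc2ccccc2Cl)c2ccccc12`) gives 100 nM. The numbers for compound 2 and compound 3 agree within the usual scatter of repeated measurements, whereas the number for compound 1 lies lower than that for compound 2 by more than that scatter.

Compound 4 (`OCc1cn(Cc2ccc(Cl)cc2Cl)c2ccccc12`) is compound 2 with a single change: chloro in place of hydrogen on an aromatic carbon, meta to a chloro group and para to a large group (chloro in place of hydrogen on an aromatic carbon). Among the measured compounds shown here, no two measured compounds differ in one place only, so the data offer no direct measure of this change. Even with their different groups, the values span only 39 nM for compound 1 to 100 nM for compound 2, so no change beyond the scatter is expected, with at most a slight drift towards a lower number. The expected step is a 1.4-fold lower number from compound 2 to compound 4 (0.15 log units; within the scatter). For compound 4 the estimated value is 70 nM, within an expected range of 25 nM to 200 nM.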

Compound 4, half-maximal inhibitory concentration: 79 nM
Compound 4: the middle estimate sits 1.1-fold (0.05 log units) below what was measured; the range from low to high includes it.
By their numbers in this assay, from the lowest: compound 1; then compounds 3, 4 and 2 (each within the scatter of the next).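

In this assay, putting a chloro group on this aromatic carbon, meta to a chloro group and para to a large group, gives a 1.3-fold lower number from compound 2 to compound 4 (0.10 log units; within the scatter) and provides the first direct measure of this change. This single pair shows that the position can carry a second chloro group without a change that can be told apart from ordinary assay variation. No measurement here explains this result.

A single small atom at one position says little about what other groups would do there, so a methoxy group, an amine or a carboxylic acid at this carbon remains an open case. On these data alone, it is also open whether the same chloro group would give a similarly small step on a compound with an aldehyde in place of the hydroxymethyl group.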